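The compounds below may be only part of what the source reports. "The series", "measured", "known", "first", "only" and "open" are said of these compounds alone.

Three compounds that share one core and differ only in the aromatic group on the far end of the amide have been measured in a functional assay on MV4-11 cells (Homo sapiens) for antiproliferative activity, with a stated time of 6 days, tested at 6.25 uM; on this read-out lower numbers stand for a weaker effect and higher numbers for a stronger effect at the one concentration tested. Compound 1 `CNC(=O)N1CCCc2ccc(NC(=O)c3ccc(-c4cc[nH]n4)cc3)cc21` gives 99.1%. Compound 2 `CNC(=O)N1CCCc2ccc(NC(=O)c3ccc(-c4ccccn4)cc3)cc21` gives 79.2%. Compound 3 `CNC(=O)N1CCCc2ccc(NC(=O)c3ccc(-c4cn[nH]c4)cc3)cc21` gives 98.3%. Compound 3 thus has the second highest of the three numbers: its value and that of compound 1 lie within the scatter of each other, while compound 2 sits clearly lower, as the step of a number 19.1 percentage points higher from compound 2 to compound 3 (beyond the scatter) shows.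

Compound 4 `CNC(=O)N1CCCc2ccc(NC(=O)c3ccc(-c4cccnc4)cc3)cc21` has not yet been measured. It differs from compound 3 in one place: pyridin-3-yl in place of 1H-pyrazol-4-yl on an aromatic carbon. Within the data shown here, two measured steps bear on this change, since each swaps a pyrazole for a pyridine or the reverse: a number 19.9 percentage points lower from compound 1 to compound 2 (beyond the scatter) and a number 19.1 percentage points higher from compound 2 to compound 3 (beyond the scatter). Both are modest, and in both the pyrazole gives the higher number. Compound 4 carries pyridin-3-yl where compound 2 carries pyridin-2-yl, so the comparison is not exact, but the same direction is expected. A modest fall is therefore expected, a number 16.3 percentage points lower from compound 3 to compound 4 (beyond the scatter). Compound 4 is estimated to give 82% in this assay, with a likely range from 65% to 97%.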

Compound 4, a percentage reported as inhibition, at one concentration (the size of the read-out at that concentration, not a potency): 92.1%
Compound 4: middle estimate off by 10.1 percentage points, on the low side, within the range that was stated.
By their numbers in this assay, from the lowest: compound 2; then compounds 4, 3 and 1 (each within the scatter of the next).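

In this assay, a pyridine at this place does not by itself set a compound apart from the pyrazoles: the change to pyridin-3-yl gives a number 6.2 percentage points lower from compound 3 to compound 4 (within the scatter) and, against the other pyrazole, a number 7 percentage points lower from compound 1 to compound 4 (within the scatter); the change from 1 hydrogen-bond donor to 0 hydrogen-bond donors therefore brings no step beyond the scatter in these two pairs. The real difference lies between the two pyridines, where pyridin-3-yl in place of pyridin-2-yl gives a number 12.9 percentage points higher from compound 2 to compound 4 (beyond the scatter), so the lower number of compound 2 belongs to pyridin-2-yl and not to pyridines in general. Nothing available here explains why these two pyridines differ.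

On these data alone, each number shows the size of the effect at a single concentration, so it remains open whether compounds 1, 3 and 4, which lie within the scatter of one another, would show a stronger or weaker effect than one another at other concentrations. As far as these compounds go, it is also open whether pyridin-4-yl would track pyridin-3-yl or pyridin-2-yl, and how a plain phenyl ring or a carboxylic acid would fare at this place.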